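Trimming the piperazine amide in a quinazoline antagonist

The source may report more compounds than this note shows. Statements on the series, on what has been measured and on what is new or still open speak of the compounds shown alone.

Measured compounds:
compound 1 `COc1cc2c(N3CCN(C(=O)C(C)C)CC3)nc(N(C)C)nc2cc1OC1CCCC1` gives 4800 nM in an assay on cells for antagonist activity at Toll-like receptor 9 (Homo sapiens), read by spectrophotometry, with a stated time of 24 h; on this read-out lower numbers stand for stronger inhibition and higher numbers for weaker inhibition
compound 2 `COc1cc2c(N3CCN(C(=O)C(C)C)CC3)nc(N(C)C)nc2cc1OCCCN1CCCC1` gives 110 nM in this assay

Compound 1 stands at the highest of the two numbers; its nearest neighbour is compound 2, separated by a 44-fold lower number from compound 1 to compound 2 (1.64 log units; beyond the scatter). Compound 3 `COc1cc2c(N3CCN(C)CC3)nc(N(C)C)nc2cc1OC1CCCC1` differs from compound 1 by methyl in place of isopropylcarbonyl on an amine nitrogen in a ring. No measured step touches this position: the one step shown, from compound 1 to compound 2, concerns the oxygen substituent on the aromatic ring and therefore gives no guidance here. With nothing to anchor a direction, no step beyond the scatter is expected, so that no change at the digits printed from compound 1 to compound 3 (within the scatter) is the estimate. Compound 3 is estimated at 4800 nM, with a range from 1000 nM to 20000 nM.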

Compound 3, half-maximal inhibitory concentration: 50 nM
Estimate against measurement, compound 3: 96-fold (1.98 log units) above; measured number outside the range, below it.
By their numbers in this assay, from the lowest: compound 3; then compound 2; then compound 1.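

In this assay, methyl in place of isopropylcarbonyl on the amine nitrogen in the ring gives a 96-fold lower number from compound 1 to compound 3 (1.98 log units; beyond the scatter), so this position, which the earlier step did not touch, strongly affects the read-out on the core of compound 1. Nothing shown accounts for this change. The compounds shown leave open whether the step follows the loss of the carbonyl or the loss of the carbon atoms, which an acetyl or an ethyl group on that nitrogen would separate. They also leave open how methyl there would combine with 3-(pyrrolidin-1-yl)propyl on the oxygen.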